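Swapping chloro for trifluoromethyl on the benzyl ring

The source may report more compounds than this note shows. Statements on the series, on what has been measured and on what is new or still open speak of the compounds shown alone.

Compound 1 `Nc1ccc(/C=C2\SC(=O)N(Cc3ccc(Cl)cc3)C2=O)cc1` carries a 4-chlorophenyl on a saturated chain carbon bound to an amide-type nitrogen in a ring. In a functional assay on CCRF-CEM cells (Homo sapiens) for cytotoxicity, read by cell counting, with a stated time of 3 days (on this read-out lower numbers stand for stronger inhibition and higher numbers for weaker inhibition), compound 1 gives 87000 nM, the highest of the two numbers reported in this assay, with compound 2 `CN1C(=O)S/C(=C\c2ccc(N)cc2)C1=O` nearest at 62000 nM, a difference of a 1.4-fold lower number from compound 1 to compound 2 (0.15 log units; within the scatter). Compound 3 `Nc1cccc(/C=C2\SC(=O)N(Cc3ccc(Cl)cc3)C2=O)c1` reaches only a limit of this assay, > 250000 nM, so that the step of an at least 2.8-fold higher number from compound 1 to compound 3 (0.45 log units; beyond the scatter) is known only as a bound; this is the case noted as the limit of > 250000 nM in this assay, at which 1 of the 3 values shown sits.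

Compound 4 `Nc1ccc(/C=C2\SC(=O)N(Cc3ccc(C(F)(F)F)cc3)C2=O)cc1` differs from compound 1 in one place: trifluoromethyl in place of chloro on an aromatic carbon. Among the measured compounds shown here, no measured step alters this aromatic carbon, so the nearest guide is the step from compound 1 to compound 2, in which removing the whole 4-chlorophenyl moved the number by a 1.4-fold lower number from compound 1 to compound 2 (0.15 log units; within the scatter), a change within the scatter. If the entire aryl group matters so little, exchanging one substituent on it is expected to matter no more.

The step from compound 1 to compound 4 in this assay is therefore estimated as a 1.0-fold higher number from compound 1 to compound 4 (0.01 log units; within the scatter), with no direction beyond the scatter. Compound 4 is expected to give 90000 nM in this assay, within a range from 40000 nM to 200000 nM.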

Compound 4, half-maximal inhibitory concentration: 32000 nM
Compound 4: middle estimate off by 2.8-fold (0.45 log units), on the high side, outside the stated range (below it).
By their numbers in this assay, from the lowest: compounds 4, 2 and 1 (each within the scatter of the next, the first and the last beyond it). At a limit, above all of these: compound 3.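

The change from chloro to trifluoromethyl gives a 2.7-fold lower number from compound 1 to compound 4 (0.43 log units; beyond the scatter) in this assay, so this aromatic carbon, para to a large group, is a place where a single substituent can move the number beyond the scatter. The earlier step, a 1.4-fold lower number from compound 1 to compound 2 (0.15 log units; within the scatter), took away the whole 4-chlorophenyl and stayed within the scatter, so a small effect from removing the aryl group does not mean that a substituent on that ring has a small effect; the two steps together show that the ring's substituent can count for more than the ring's presence alone would suggest. The values shown offer no measurement that explains why trifluoromethyl gives the lower number here.

Going by these compounds, it remains open whether the lower number is particular to trifluoromethyl or would also appear with another group on this carbon, such as bromo, methoxy, nitrile or plain hydrogen. On these data alone, it is equally open whether the same exchange would lower the number in the 3-aminophenyl series of compound 3, whose value of > 250000 nM is only a limit.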